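Closing the hydrazide: from compound 1 to compound 4

The compounds below may be only part of what the source reports. "The series", "measured", "known", "first", "only" and "open" are said of these compounds alone.

Compound 1 `Cc1ccccc1NNC(=O)c1ccccc1NS(=O)(=O)c1cnc(O)nc1O` reaches only the limit > 20000 nM in a functional assay on MDA-MB-231 cells (Homo sapiens) for antiproliferative activity, read by MTT assay, with a stated time of 24 h; a higher number here means a weaker inhibitor, a lower number a stronger inhibitor; at that limit it sits, as shown by the limit of > 20000 nM in this assay, at which 1 of the 3 values shown sits. Compound 4 `O=C(NNC(=O)c1ccccc1NS(=O)(=O)c1cnc(O)nc1O)c1ccccc1Cl` differs from it by (2-chlorophenyl)carbonyl in place of 2-methylphenyl on an amine nitrogen. Among the compounds with values here, no measured pair covers this change. Within the data shown here, the only measured step, a 1.2-fold higher number from compound 2 to compound 3 (0.07 log units; within the scatter), concerns compound 2 `CCCCOc1ccc(C(=O)NNC(=O)c2ccc(NS(=O)(=O)c3cnc(O)nc3O)cc2)cc1` with 11900 nM and compound 3 `O=C(NNC(=O)c1ccccc1Cl)c1ccc(NS(=O)(=O)c2cnc(O)nc2O)cc1` with 13900 nM, both carrying the same carbonyl-linked hydrazide as compound 4, though on a core arranged differently from that of compound 1. Their values lie below the limit seen for compound 1, so compound 4 is expected to give a number rather than a limit, with the step of an at least 1.3-fold lower number from compound 1 to compound 4 (0.12 log units; that floor lies within the scatter) estimated toward a lower value. For compound 4 the estimate is 15000 nM, within 6000 nM to 40000 nM.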

Compound 4, half-maximal inhibitory concentration: 8310 nM
Estimate against measurement, compound 4: 1.8-fold (0.26 log units) above; the measured number falls inside the stated range.
By their numbers in this assay, from the lowest: compounds 4, 2 and 3 (each within the scatter of the next). At a limit, above all of these: compound 1.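

At this amine nitrogen, (2-chlorophenyl)carbonyl in place of 2-methylphenyl gives in this assay an at least 2.4-fold lower number from compound 1 to compound 4 (0.38 log units; beyond the scatter). Compound 4 shows that the carbonyl-linked hydrazide also gives a number rather than a limit on the core of compound 1, as it does in compound 2 and compound 3. The step is only a floor, and compound 1 remains the one compound at a limit: the limit of > 20000 nM in this assay, at which 1 of the 4 values shown sits.

The compounds shown do not separate the added carbonyl from the exchange of methyl for chlorine. Going by these compounds, how a (2-methylphenyl)carbonyl group or an unsubstituted benzoyl group would read at this nitrogen remains open.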